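Solubility of two chloropyridyl amides on a shared core

This account rests on a few compounds, and the source may have more. Where it says the series, first, only, none or still open, it means among the compounds named here.

Compound 1 `O=C(O)/C=C/C(=O)Nc1cccc(-c2nc3ccccc3s2)c1` carries the shared core with a 2-carboxyethenyl group on the carbonyl carbon. Among the measured compounds shown here, in a physicochemical assay for solubility, in phosphate buffer, measured as kinetic solubility, with a stated time of 18 h, at pH 7.4 (on this read-out lower numbers stand for lower solubility and higher numbers for higher solubility), compound 1 gives 56000 nM, the highest of the two numbers measured so far. Its nearest measured neighbour is compound 2 `O=C(Nc1cccc(-c2nc3ccccc3s2)c1)c1cccnc1Cl`, which in this assay gives 520 nM; the step of a 110-fold lower number from compound 1 to compound 2 (2.03 log units; beyond the scatter) came with a 2-chloropyridin-3-yl group in place of the 2-carboxyethenyl group. Compound 3 `O=C(Nc1cccc(-c2nc3ccccc3s2)c1)c1ccncc1Cl` differs from compound 1 by 3-chloropyridin-4-yl in place of 2-carboxyethenyl on a carbonyl carbon. For the measured compounds named here, only the step from compound 1 to compound 2 bears on this change, and it was large and downward. Since the group entering compound 3 is also a chloropyridinyl ring replacing the same acid-bearing chain, a step of comparable size in the same direction is expected, a 93-fold lower number from compound 1 to compound 3 (1.97 log units; beyond the scatter). Compound 3 is therefore estimated to give about 600 nM in this assay, within a range from 150 nM to 2500 nM.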

Compound 3, solubility: 320 nM
Compound 3: the middle estimate sits 1.9-fold (0.27 log units) above what was measured, within the range that was stated.
By their numbers in this assay, from the lowest: compounds 3 and 2 (each within the scatter of the next); then compound 1.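

In this assay, 3-chloropyridin-4-yl in place of 2-carboxyethenyl on the carbonyl carbon gives a second large step (a 180-fold lower number from compound 1 to compound 3 (2.24 log units; beyond the scatter)), so the large step seen earlier no longer rests on a single chloropyridinyl group. Exchanging one chloropyridinyl group for the other gives a difference within the scatter (a 1.6-fold lower number from compound 2 to compound 3 (0.21 log units; within the scatter)), so this read-out does not tell the two groups apart at this position. Nothing measured here accounts for the size of the steps from the chain to either ring.

The compounds shown leave open whether the chlorine plays any part, since they do not show a pyridinyl ring without it or with an amine in its place. They also leave open whether a carboxylic acid on such a ring would bring the number back towards that of compound 1.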